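Moving a Methyl Around the Benzylsulfanyl Ring

The source may hold more compounds than are shown below. What is called first, only, known or untested is meant among the compounds shown, and "the series" means these compounds.

Measured so far in a functional assay on HeLa cells (Homo sapiens) for antiproliferative activity, read by MTT assay, with a stated time of 72 h; on this read-out higher numbers stand for weaker inhibition and lower numbers for stronger inhibition:
Compound 1 `C/C(C#Cc1ccccc1)=N\N/C(N)=N/S(=O)(=O)c1cc(C)c(Cl)cc1SCc1ccccc1C`: 270000 nM
Compound 2 `C/C(C#Cc1ccccc1)=N\N/C(N)=N/S(=O)(=O)c1cc(C)c(Cl)cc1SCc1cccc(C)c1`: 105000 nM

Compound 2 stands lowest of the two numbers; compound 1 sits higher by a 2.6-fold lower number from compound 1 to compound 2 (0.41 log units; beyond the scatter). Compound 3 `C/C(C#Cc1ccccc1)=N\N/C(N)=N/S(=O)(=O)c1cc(C)c(Cl)cc1SCc1ccc(C)cc1` is not yet measured and differs from compound 2 by 4-methylphenyl in place of 3-methylphenyl on a saturated chain carbon bound to a sulfur. Going by the values given here, the one step that bears on this, from 2-methylphenyl to 3-methylphenyl, was a 2.6-fold lower number from compound 1 to compound 2 (0.41 log units; beyond the scatter), a modest shift; no measured step reaches 4-methylphenyl. Compound 3 is therefore expected to move only slightly, by a 1.2-fold lower number from compound 2 to compound 3 (0.07 log units; within the scatter), with an estimated 90000 nM (range 35000 nM to 250000 nM).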

Compound 3, half-maximal inhibitory concentration: 110000 nM
Compound 3: middle estimate off by 1.2-fold (0.09 log units), on the low side; low and high end bracket the measured number.
By their numbers in this assay, from the lowest: compounds 2 and 3 (each within the scatter of the next); then compound 1.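

In this assay, the swap to 4-methylphenyl gives a 1.0-fold higher number from compound 2 to compound 3 (0.02 log units; within the scatter) and so cannot be told apart from 3-methylphenyl. Against 2-methylphenyl, the same group gives a 2.5-fold lower number from compound 1 to compound 3 (0.39 log units; beyond the scatter) and matches the earlier step, so among these three compounds only 2-methylphenyl stands apart, with the higher number. No evidence at hand explains that difference. Going by these compounds, all three compounds carry a methyl on this ring, so it stays open how a methoxy, an amine or a carboxylic acid there would read.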